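Halogen swap on the pendant aryl group: cytotoxicity notes

The compounds below may be only part of what the source reports. "The series", "measured", "known", "first", "only" and "open" are said of these compounds alone.

In an ADME assay on MT4 cells (Homo sapiens) for cytotoxicity (a higher number here means that more compound is tolerated, a lower number that less compound is tolerated), compound 3 `Cc1ccc(NC(=O)CSc2snnc2-c2ccc(Cl)cc2Cl)c(Br)c1` gives only a limit, > 255000 nM. Compound 1 `CCOC(=O)c1ccc(NC(=O)CSc2snnc2-c2ccc(Cl)cc2Cl)c(Br)c1` likewise gives a limit, > 228000 nM. Compound 2 `Cc1ccc(NC(=O)CSc2snnc2-c2ccccc2)c(Br)c1` also gives a limit, > 297000 nM. The step that the two limits leave unreadable from compound 1 to compound 3 and the step that the two limits leave unreadable from compound 2 to compound 3 thus have no readable size; all three values sit at limits, (the limit of > 228000 nM in this assay, at which 1 of the 3 values shown sits), the limit of > 255000 nM in this assay, at which 1 of the 3 values shown sits, and (the limit of > 297000 nM in this assay, at which 1 of the 3 values shown sits). Compound 4 `Cc1ccc(NC(=O)CSc2snnc2-c2ccc(F)cc2F)c(Br)c1` differs from compound 3 by 2,4-difluorophenyl in place of 2,4-dichlorophenyl on an aromatic carbon. Among the compounds with values here, no measured step covers this change, and none of the measured steps in this assay is readable, so the step that the limit leaves unreadable from compound 3 to compound 4 is estimated as nothing beyond the scatter, with a limit again the most likely outcome. Compound 4 is expected to give 280000 nM in this assay, with a range from 120000 nM to 600000 nM.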

Compound 4, half-maximal cytotoxic concentration: > 273000 nM
Compound 4 was reported as a limit; the forecaster's own chance of this, stated with the estimate: 85%; the middle value is on the limit's open side.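

Compound 4 also gives only a limit, > 273000 nM, so the steps to it from compound 2 and compound 3 cannot be read. The compounds shown leave open at what concentration any of the four becomes cytotoxic in this assay.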